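The compounds below may be only part of what the source reports. "The series", "measured", "known", "first", "only" and "open" are said of these compounds alone.

Measured so far in an ADME assay on liver (Mus musculus) for metabolic stability, using microsomes, with a stated time of 10 min, tested at 0.5 uM; a lower number here means that less of the compound is left, a higher number that more of the compound is left:
compound 1 `Cc1ccncc1-c1cccc2c1cnn2-c1cccnn1` gives 17%
compound 2 `Cc1ccncc1-c1cccc2c1ncn2-c1cnccn1` gives 59%
compound 3 `Cc1ccncc1-c1cccc2c1cnn2-c1ccc(F)cc1` gives 11%

Compound 2 stands highest of the three, and compound 1 and compound 3 both lie beyond the scatter under it. Compound 4 `Cc1ccncc1-c1cccc2c1ncn2-c1cscn1` keeps the core of compound 2 and carries 1,3-thiazol-4-yl in place of pyrazin-2-yl on an aromatic nitrogen. Among the measured compounds shown here, only one measured step changes the group on such a nitrogen, and it sits on a core other than that of compound 2. That step is a number 6 percentage points lower from compound 1 to compound 3 (within the scatter) and so offers no sign of a large move. For the measured compounds named here, no step on the core of compound 2 has been measured, so the guide is weak. Starting from the high value of compound 2 at 59%, a small fall is expected, most likely not beyond the scatter. The estimated step is a number 7 percentage points lower from compound 2 to compound 4 (within the scatter) and it carries wide uncertainty. Compound 4 is expected at 52% (32% to 72%) in this assay by this estimate.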

Compound 4, percent of the compound remaining: 42%
The estimate for compound 4 lay 10 percentage points above the measured number, within the range that was stated.
By their numbers in this assay, from the lowest: compounds 3 and 1 (each within the scatter of the next); then compound 4; then compound 2.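

In this assay the group on the aromatic nitrogen of the core of compound 2 proves able to move the number beyond the scatter: 1,3-thiazol-4-yl in place of pyrazin-2-yl gives a number 17 percentage points lower from compound 2 to compound 4 (beyond the scatter) on that core. Among the compounds shown here, the one earlier change at such a nitrogen, a number 6 percentage points lower from compound 1 to compound 3 (within the scatter) on another core, had given no sign of a move of this kind, so that small step cannot be taken as a rule for this position. Nothing at hand accounts for the fall.

Going by these compounds, a single step cannot separate the five-membered ring from the sulfur it brings, and the same exchange on the core of compound 1 remains unknown. On these data alone, how an amine, a carboxylic acid or a longer chain on this nitrogen would fare in this assay also stays open.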